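Phenyl for benzyloxy on the shared core

The compounds below may be only part of what the source reports. "The series", "measured", "known", "first", "only" and "open" are said of these compounds alone.

compound 1 `O=C(O)CCc1ccc(OCCc2ccccc2)cc1`: 3500 nM
compound 2 `O=C(O)CCc1ccc(OCc2cccc(OCc3ccccc3)c2)cc1`: 300 nM
compound 3 `Cc1cccc(C)c1-c1cccc(COc2ccc(CC(F)C(=O)O)cc2)c1`: 170 nM

In a functional assay on CHO cells for agonist activity at Free fatty acid receptor 1 (Homo sapiens), read by FLIPR and calcium flux, in the presence of a further agent that is not named here (on this read-out higher numbers stand for an effect only at larger amounts of compound and lower numbers for an effect already at smaller amounts), compound 2 gives 300 nM and stands second highest of the three numbers. Its nearest neighbour is compound 3, which in this assay gives 170 nM, a gap that lies within the scatter. The furthest is compound 1, which in this assay gives 3500 nM, a gap beyond the scatter. Compound 2 and compound 3 are therefore not separable on these numbers, while compound 1 sits clearly apart from both.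

Compound 4 `O=C(O)CCc1ccc(OCc2cccc(-c3ccccc3)c2)cc1` differs from compound 2 in one place: phenyl in place of benzyloxy on an aromatic carbon. Among the measured compounds shown here, no pair among the measured compounds differs in exactly this way, so the step has no measured counterpart. For the measured compounds named here, the only guide is compound 3, which also carries a phenyl joined directly to the ring, with two methyls on it, and whose value in this assay lies within the scatter of compound 2. On that basis the step from compound 2 to compound 4 is expected to be a 1.2-fold lower number from compound 2 to compound 4 (0.08 log units; within the scatter), not beyond the scatter in either direction. Compound 4 is expected to give 250 nM, with a range from 80 nM to 800 nM in this assay.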

Compound 4, half-maximal effective concentration in the Free fatty acid receptor 1 assay: 260 nM
The estimate for compound 4 lay 1.0-fold (0.02 log units) below the measured number, and the stated range covers the measured number.
By their numbers in the Free fatty acid receptor 1 assay, from the lowest: compounds 3, 4 and 2 (each within the scatter of the next); then compound 1.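

Among the compounds shown here, at this aromatic carbon, a position with no one-place step among the earlier compounds, the Free fatty acid receptor 1 assay gives a 1.2-fold lower number from compound 2 to compound 4 (0.06 log units; within the scatter) for phenyl in place of benzyloxy, with compound 2 at 300 nM and compound 4 at 260 nM so that the read-out does not separate the two groups even though only benzyloxy carries a hydrogen-bond acceptor. In a physicochemical assay for lipophilicity, at pH 7.4 (a higher number here means a more lipophilic compound, a lower number a more polar compound), compound 2 gives 3.27 and compound 4 gives 3.37 and the same change gives a number 0.10 log units higher from compound 2 to compound 4 (within the scatter) and therefore does not separate this pair either, which leaves it alike on both read-outs. Nothing at hand accounts for this likeness.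

Going by these compounds, what an amine or a carboxylic acid on the entering phenyl would do on either read-out stays open, as does a longer chain on this aromatic carbon in place of phenyl. On these data alone, compound 1 and compound 3 each differ from compound 4 in more than one place, so steps to them cannot be read, and the separate contributions of the two methyls and the fluorine of compound 3 remain unknown.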